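The compounds below may be only part of what the source reports. "The series", "measured", "known", "first", "only" and "open" are said of these compounds alone.

Compound 1 `CCCC(=O)N1CCN(c2nc(=O)c3cc(C(F)(F)F)cc([N+](=O)[O-])c3s2)CC1` was tested in an ADME assay on Vero cells (Chlorocebus sabaeus) for cytotoxicity, read by MTT assay, with a stated time of 72 h; on this read-out lower numbers stand for higher toxicity in this test and higher numbers for lower toxicity in this test. In this assay compound 1 gave only a limit, > 125000 nM, so no number is known for it. Two related compounds were run alongside. Compound 2 `Cc1ccc(C(=O)N2CCN(c3nc(=O)c4cc(C(F)(F)F)cc([N+](=O)[O-])c4s3)CC2)cc1` also gave only a limit in this assay, > 125000 nM. Compound 3 `CC(C)CC(=O)N1CCN(c2nc(=O)c3cc(C(F)(F)F)cc([N+](=O)[O-])c3s2)CC1` likewise reached only a limit in this assay, > 125000 nM. Among the measured compounds shown here, because of the limit of > 125000 nM in this assay, at which 3 of the 3 values shown sit, none of the measured steps can be read: the step that the two limits leave unreadable from compound 1 to compound 2, the step that the two limits leave unreadable from compound 1 to compound 3 and the step that the two limits leave unreadable from compound 2 to compound 3 all stay hidden behind the same limit.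

The next compound, compound 4 `O=C(C1CCC1)N1CCN(c2nc(=O)c3cc(C(F)(F)F)cc([N+](=O)[O-])c3s2)CC1`, differs from compound 1 in one place: cyclobutyl in place of propyl on a carbonyl carbon. For the measured compounds named here, no measured step speaks to this change, and every value so far sits at the limit. The step from compound 1 to compound 4 in this assay is therefore expected to be a step that the limit leaves unreadable from compound 1 to compound 4, which is to say nothing beyond the scatter. Compound 4 is estimated to give 150000 nM in this assay, within a range from 70000 nM to 320000 nM, most likely again reported only as a limit.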

Compound 4, half-maximal cytotoxic concentration: > 125000 nM
Compound 4: only a limit was reported; the forecaster's own chance of this, stated with the estimate: 80%; the middle value does not contradict the limit.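

Compound 4 joins compound 1, compound 2 and compound 3, and no step among them can be read, because each result is a limit and not a number: the limit of > 125000 nM in this assay, at which 4 of the 4 values shown sit.

On these data alone, whether any of these groups on the carbonyl carbon changes the read-out in this assay stays open.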